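Swapping an Acid-Bearing Chain for Butyl on the Core

This account rests on a few compounds, and the source may have more. Where it says the series, first, only, none or still open, it means among the compounds named here.

Measured so far, in a functional assay on FaDu cells (Homo sapiens) for cytotoxicity, read by MTT assay, with a stated time of 72 h; a lower number here means that less compound is tolerated, a higher number that more compound is tolerated:
compound 1, `COc1ccc(NC(=O)C(=O)c2cn(C(C)(C)COCC(=O)O)c3ccccc23)cn1`, gives > 10000 nM
compound 2, `COCCn1cc(C(=O)C(=O)Nc2ccc(OC(F)(F)F)cc2)c2ccccc21`, gives 487 nM
compound 3, `COCCn1cc(C(=O)C(=O)Nc2ccc(OC)nc2)c2cccnc21`, gives 27 nM

Compound 1 stands apart from the other two. Its result is not a number but a limit of the assay, as the limit of > 10000 nM in this assay, at which 1 of the 3 values shown sits, records, so for compound 1 only this limit is known. Compound 2 and compound 3, which carry a shorter chain on the same aromatic nitrogen, each give a measured number, with compound 3 lower than compound 2.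

Compound 4, `CCCCn1cc(C(=O)C(=O)Nc2ccc(OC)nc2)c2ccccc21`, has not yet been measured. It differs from compound 1 in one place: a group of 4 heavy atoms (4 carbon; no ring) in place of a group of 9 heavy atoms (6 carbon, 3 oxygen; no ring), on an aromatic nitrogen. The long chain that ends in a carboxylic acid is gone, and a plain butyl chain stands on the aromatic nitrogen instead, while the methoxypyridine amide of compound 4 matches that of compound 3.

Within the data shown here, no step between measured compounds that change only one place is available, so any expectation rests on the three values as they stand. Compound 4 is expected to leave the limit behind and give a measured number, close to where compound 2 and compound 3 fall, with 120 nM estimated and a range from 20 nM to 800 nM. That expectation corresponds to a large step of an at least 83-fold lower number from compound 1 to compound 4 (1.92 log units; beyond the scatter) toward less compound being tolerated.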

Compound 4, concentration lethal to 50% of the cells: 18 nM
For compound 4 the middle estimate is 6.7-fold (0.82 log units) above the measured one; the whole stated range lies above it.
By their numbers in this assay, from the lowest: compounds 4 and 3 (each within the scatter of the next); then compound 2. At a limit, above all of these: compound 1.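

In this assay, among these compounds, replacing the long acid-bearing chain on the aromatic nitrogen with butyl gives an at least 550-fold lower number from compound 1 to compound 4 (2.74 log units; beyond the scatter), the first comparison here in which only this group changes. The true size of this step stays open, as compound 1 is known only through a limit: the limit of > 10000 nM in this assay, at which 1 of the 4 values shown sits. Even so, this position on the shared core is shown to matter greatly in this assay, since this one change takes the result from a limit to a measured number, and the methoxypyridine amide and the core of compound 1 alone do not bring the number down.

This single swap removes the whole chain at once, so the carboxylic acid at its end, its ether oxygen and its branched carbon cannot be told apart as the source of the difference. A butyl chain ending in a carboxylic acid or an amine, or a longer plain alkyl chain, would show how much of the step follows the end group and how much follows the chain itself.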